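The source may hold more compounds than are shown below. What is called first, only, known or untested is meant among the compounds shown, and "the series" means these compounds.

Of the compounds shown here, three sharing one core have been tested in an assay on isolated protein for inhibition of high affinity 3',5'-cyclic-AMP phosphodiesterase 7A (Homo sapiens), read by cAMP accumulation, with a stated time of 20 min; on this read-out lower numbers stand for stronger inhibition and higher numbers for weaker inhibition. Compound 1 `CCCCCn1c(-c2ccc(OC)cc2)nc2c(N)ccnc21` gives only the limit of the assay, > 200000 nM. Compound 2 `CCCCCn1c(-c2ccccc2)nc2c(NCc3ccccc3)ccnc21` likewise gives the limit, > 200000 nM. Compound 3 `CCCCCn1c(-c2ccco2)nc2c(NCc3ccccc3)ccnc21` also gives the limit, > 200000 nM. The step from compound 2 to compound 3, a step that the two limits leave unreadable from compound 2 to compound 3, cannot be read, because of the limit of > 200000 nM in this assay, at which 3 of the 3 values shown sit. Compound 3 thus stands at the limit, with no measured number among the three. Compound 4 `CCCCCn1c(-c2ccco2)nc2c(NCCCOC)ccnc21` differs from compound 3 by 2-methoxyethyl in place of phenyl on a saturated chain carbon bound to a nitrogen on an aromatic ring. Within the data shown here, no measured step bears on this change, and the limit of > 200000 nM in this assay, at which 3 of the 3 values shown sit, gives no direction, so compound 4 is expected to remain at the limit, a step that the limit leaves unreadable from compound 3 to compound 4 of no readable size. The estimate for compound 4 is 300000 nM, within 100000 nM to 2000000 nM.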

Compound 4, half-maximal inhibitory concentration: 34200 nM
Compound 4: the middle estimate sits 8.8-fold (0.94 log units) above what was measured; the whole stated range lies above it.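

Replacing benzylamino with (3-methoxypropyl)amino, with furan-2-yl kept in place, gives an at least 5.8-fold lower number from compound 3 to compound 4 (0.76 log units; beyond the scatter) in this assay. Among these compounds, this shows that the group on this amino nitrogen can move the read-out off the limit, which the earlier compounds could not show. Of the compounds shown, only compound 4 gives a number rather than a limit: the limit of > 200000 nM in this assay, at which 3 of the 4 values shown sit.

The change removes a phenyl ring and brings in a chain oxygen at once, and these compounds cannot tell the two apart. From the compounds shown here alone, a plain butyl chain or a 3-hydroxypropyl group at this place would address that question, and how much further the number can fall also stays open.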